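Adding a formyl group to a dinitro compound

The source may hold more compounds than are shown below. What is called first, only, known or untested is meant among the compounds shown, and "the series" means these compounds.

Compound 1 `Cc1cccc(C)c1Oc1ccc([N+](=O)[O-])c(Nc2ccc(C#N)cc2)c1` gives 69600 nM
Compound 2 `Cc1cc(C=O)cc(C)c1Oc1ccc([N+](=O)[O-])c(Nc2ccc(C#N)cc2)c1` gives 14200 nM
Compound 3 `Cc1cccc(C)c1Oc1cc(Nc2ccc(C#N)cc2)c([N+](=O)[O-])cc1[N+](=O)[O-]` gives > 61800 nM as a limit of the assay, not a number

All three values come from an ADME assay on H9 cells (Homo sapiens) for cytotoxicity, read by XTT assay, with a stated time of 6 days (on this read-out lower numbers stand for higher toxicity in this test and higher numbers for lower toxicity in this test), alone. Compound 3 stands at a limit, and the limit of > 61800 nM in this assay, at which 1 of the 3 values shown sits, is all that is known of it. Compound 4 `Cc1cc(C=O)cc(C)c1Oc1cc(Nc2ccc(C#N)cc2)c([N+](=O)[O-])cc1[N+](=O)[O-]` differs from compound 3 in one place. The count of that difference is formyl in place of hydrogen on an aromatic carbon and the change is formyl in place of hydrogen on an aromatic carbon, meta to two methyl groups and para to a large group.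

The same swap has one measured case, namely a 4.9-fold lower number from compound 1 to compound 2 (0.69 log units; beyond the scatter) in the series. The other measured step offers no size to work with, since it reads a step that the limit leaves unreadable from compound 1 to compound 3 here. On these data alone, on the single formyl case alone, a modest move of similar size toward lower numbers is expected in this assay here, although the exact starting point is unknown. The expected change is an at least 4.1-fold lower number from compound 3 to compound 4 (0.61 log units; beyond the scatter) on this estimate. For compound 4 the estimated value is 15000 nM within an expected range of 6000 nM to 50000 nM in this test.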

Compound 4, half-maximal cytotoxic concentration: 57900 nM
Estimate against measurement, compound 4: 3.9-fold (0.59 log units) below; the whole stated range lies below it.
By their numbers in this assay, from the lowest: compound 2; then compounds 4 and 1 (each within the scatter of the next).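

In this assay, the formyl swap on its second core gives an at least 1.0-fold lower number from compound 3 to compound 4 (0.02 log units; that floor lies within the scatter) and so does not confirm a drop like the one seen on the core of compound 1. Compound 3 reads > 61800 nM as a limit of the assay, not a number. The added nitro now has a readable size where the formyl group is present, as it gives a 4.1-fold higher number from compound 2 to compound 4 (0.61 log units; beyond the scatter) on that formyl-bearing core, while the same swap without formyl cannot be read.

On these data alone, how large the formyl step truly is on the dinitro core stays open, and so does whether it differs from the step on the core of compound 1. Also open, as far as these compounds go, is whether an amine or a carboxylic acid on that same aromatic carbon would shift the number as formyl does.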